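Replacing the N-aryl group of compound 3 with a methyl

A few compounds are considered here, and "the series" means these few. Any claim that something is new, unique, unknown or untested is made for them only; others in the source may bear on it.

Three ureas built on one shared core have been measured in an assay on isolated protein for inhibition of Ephrin type-A receptor 2 (Homo sapiens), read by thermal shift assay, tested at 10 uM; on this read-out lower numbers stand for weaker stabilisation of the target and higher numbers for stronger stabilisation of the target against heat. Compound 1 `CC(C)(C)c1cc(NC(=O)Nc2cc(C(F)(F)F)cc(C(F)(F)F)c2)n(-c2ccccc2)n1` gives 0.8 degrees C, compound 2 `Cc1ccc(NC(=O)Nc2cc(C(C)(C)C)nn2-c2ccccc2)cc1` gives 1.7 degrees C, and compound 3 `Cc1ccc(-n2nc(C(C)(C)C)cc2NC(=O)Nc2cc(C(F)(F)F)cc(C(F)(F)F)c2)cc1` gives 0.8 degrees C. All three values lie within the usual scatter of one another, so compound 3 sits level with compound 1 and no order among the three can be read from these numbers.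

Compound 4 `Cn1nc(C(C)(C)C)cc1NC(=O)Nc1cc(C(F)(F)F)cc(C(F)(F)F)c1` arises from compound 3 by the change (methyl in place of 4-methylphenyl on an aromatic nitrogen). Going by the values given here, the only measured step touching this region is no change at the digits printed from compound 1 to compound 3 (within the scatter), which shows that altering the ring on that nitrogen left the melting-temperature shift unchanged. Among the compounds with values here, the removal of the whole ring in favour of a methyl is a larger change, and no measured pair covers it, so the step of a number 0.10 degrees C higher from compound 3 to compound 4 (within the scatter) is expected to stay within the scatter. Compound 4 is therefore expected to give 0.9 degrees C, with a range from 0 degrees C to 2 degrees C.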

Compound 4, shift of the target's melting temperature: 0.4 degrees C
Estimate against measurement, compound 4: 0.50 degrees C above, within the range that was stated.
By their numbers in this assay, from the lowest: compounds 4, 1, 3 and 2 (each within the scatter of the next, the first and the last beyond it).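

Across this assay, the whole aromatic ring on this nitrogen gives way to a methyl with the melting-temperature shift staying within the scatter: the step is a number 0.40 degrees C lower from compound 3 to compound 4 (within the scatter), and for the unsubstituted ring it is a number 0.40 degrees C lower from compound 1 to compound 4 (within the scatter). The earlier step covered only a methyl added to that ring, whereas these two show that neither 4-methylphenyl nor phenyl is needed on this nitrogen for a shift of this size, even with far fewer heavy atoms there. No supporting measurement accounts for this result.

From the compounds shown here alone, what stays open is whether any group on this nitrogen can move the shift beyond the scatter in either direction. A longer chain, a carboxylic acid or an amine there would test this.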